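Side-chain amine swap: benzylamino to dipentylamino

The compounds below may be only part of what the source reports. "The series", "measured", "known", "first", "only" and "open" are said of these compounds alone.

Values in a functional assay (aorta) with Rattus norvegicus as the target; a lower number here means a stronger inhibitor, a higher number a weaker inhibitor
- compound 1 `CC(C)c1cn2ccccc2c1S(=O)(=O)c1ccc(OCCCNCc2ccccc2)cc1` gives 22.8 nM
- compound 2 `CC(C)c1cn2ccccc2c1S(=O)(=O)c1ccc(OCCCN2CCN(c3ccccc3)CC2)cc1` gives 205 nM
- compound 3 `CCCCCCCCN(CCCCCCCC)CCCOc1ccc(S(=O)(=O)c2c(C(C)C)cn3ccccc23)cc1` gives 30100 nM

Compound 1 has the lowest number of the three. Unmeasured compound 4 `CCCCCN(CCCCC)CCCOc1ccc(S(=O)(=O)c2c(C(C)C)cn3ccccc23)cc1` has dipentylamino in place of benzylamino on a saturated chain carbon, three bonds along the chain from an oxygen on an aromatic ring. Within the data shown here, the only measured step at this place, a 9.0-fold higher number from compound 1 to compound 2 (0.95 log units; beyond the scatter), also removes benzylamino and raises the number. Compound 3 carries dioctylamino there and stands much higher at 30100 nM. Among the measured compounds shown here, no measured step leads directly to dipentylamino, so the expectation is loose. A rise is expected, somewhat beyond the step to compound 2 but well short of the number for compound 3. The expected step is a 13-fold higher number from compound 1 to compound 4 (1.12 log units; beyond the scatter). The estimate for compound 4 is 300 nM, with an expected range of 40 nM to 3000 nM.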

Compound 4, half-maximal inhibitory concentration: 89.6 nM
Beside the measured number, compound 4's estimate is 3.3-fold (0.52 log units) above it; measured number inside the range.
By their numbers in this assay, from the lowest: compound 1; then compound 4; then compound 2; then compound 3.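

Losing the benzylamino ring costs little at this position, a 3.9-fold higher number from compound 1 to compound 4 (0.59 log units; beyond the scatter), so an open dialkylamine on the chain keeps the number well under that of compound 3. Dipentylamino also outperforms the 4-phenylpiperazin-1-yl group, a 2.3-fold lower number from compound 2 to compound 4 (0.36 log units; beyond the scatter). Chain length therefore matters sharply within the dialkylamines: compound 4 gives 89.6 nM, whereas compound 3, with dioctylamino, gives 30100 nM.

Where the number climbs between these two chain lengths stays open, as dihexylamino would fall there, and shorter chains such as dimethylamino are equally unresolved. No evidence on the cause of these differences is available.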